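Quinoline nitrile series: phenyl to pyridin-2-yl amide

This account rests on a few compounds, and the source may have more. Where it says the series, first, only, none or still open, it means among the compounds named here.

Measured in an assay on cells with Cystic fibrosis transmembrane conductance regulator variant F508del (Homo sapiens) as the target, read by fluorescence, with stated times of 24 h and 30 min; on this read-out higher numbers stand for an effect only at larger amounts of compound and lower numbers for an effect already at smaller amounts:
Compound 1 `COc1ccc(Cl)cc1Cc1cc(-c2sc(NC(=O)C(C)(C)C)nc2C)nn1C(=O)N1CCOCC1` gives 1000 nM
Compound 2 `Cc1cc(C)c2cc(C#N)c(NCCNC(=O)c3ccccc3)nc2c1` gives 100000 nM
Compound 3 `Cc1cc(C)c2cc(C#N)c(N3CCN(C(=O)c4ccccn4)CC3)nc2c1` gives 100000 nM

Compound 2 stands level with compound 3 at the digits shown, the two together being the highest numbers of the three; the gap between them is within the scatter, so no order can be read between them. Compound 1 sits furthest from compound 2, with the lower number of the two, a gap well beyond the scatter. Compound 1 shares no core with compound 2 or compound 3, so its number says nothing about the step considered here.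

The next compound, compound 4 `Cc1cc(C)c2cc(C#N)c(NCCNC(=O)c3ccccn3)nc2c1`, differs from compound 2 in one place:
pyridin-2-yl in place of phenyl on a carbonyl carbon

Going by the values given here, no step between two measured compounds isolates this change. The nearest comparison is compound 3, which already carries a (pyridin-2-yl)carbonyl on its amide-type nitrogen and gives 100000 nM, a number that does not separate from compound 2. On that basis the step is expected to be none beyond the scatter, no change at the digits printed from compound 2 to compound 4 (within the scatter).

Compound 4 is therefore estimated at 100000 nM in this assay, with a range from 40000 nM to 200000 nM.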

Compound 4, half-maximal effective concentration: 100000 nM
For compound 4 middle estimate and measured number coincide at the digits printed, within the range that was stated.
By their numbers in this assay, from the lowest: compound 1; then compounds 2, 3 and 4 (each within the scatter of the next).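

In this assay, the change from phenyl to pyridin-2-yl on a carbonyl carbon whose other neighbour is an amide-type nitrogen can now be read directly, and the step is no change at the digits printed from compound 2 to compound 4 (within the scatter). The earlier compounds shown here held no pair differing only in this place, whereas this pair shows that exchanging the carbon-only aromatic ring for one with a single hetero atom, and so adding one hydrogen-bond acceptor, gives no separation at this position. The data on hand offer no explanation for this outcome.

Open, from the compounds shown here alone, is whether a pyridin-3-yl or pyridin-4-yl ring, or a phenyl carrying an amine or a carboxylic acid, on the same carbonyl carbon would give a number that separates from compound 2 at 100000 nM in this assay. Also open, going by these compounds, is whether the phenyl to pyridin-2-yl step would read the same with a longer chain in place of the one that carries the amide-type nitrogen in compound 4.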